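This account rests on a few compounds, and the source may have more. Where it says the series, first, only, none or still open, it means among the compounds named here.

Compound 3 `CC(C)(Oc1ccc(Cl)cc1)C(=O)NCCOC(=S)Nc1ccccc1` is one of three close relatives tested in an ADME assay on WI-38 cells (Homo sapiens) for cytotoxicity, read by MTT assay, with a stated time of 48 h; on this read-out lower numbers stand for stronger inhibition and higher numbers for weaker inhibition. In this assay compound 3 gives > 800000 nM, which is a limit of the assay rather than a number. Compound 1 `Cc1ccc(NC(=S)OCCNC(=O)C(C)(C)Oc2ccc(Cl)cc2)cc1` and compound 2 `CC(C)(Oc1ccc(Cl)cc1)C(=O)NCCOC(=S)Nc1ccc([N+](=O)[O-])cc1Cl` share the same core. In this assay compound 1 gives > 800000 nM, also a limit. In this assay compound 2 gives > 800000 nM, a limit as well. The steps among them, a step that the two limits leave unreadable from compound 1 to compound 2, a step that the two limits leave unreadable from compound 1 to compound 3 and a step that the two limits leave unreadable from compound 2 to compound 3, have no size because of the limit of > 800000 nM in this assay, at which 3 of the 3 values shown sit. Compound 4 `CC(C)(Oc1ccc(Cl)cc1)C(=O)NCCOC(=S)Nc1ccc(F)cc1` carries fluoro in place of hydrogen on an aromatic carbon. Among the measured compounds shown here, no measured step bears on this change; the only visible pattern is that every value reached the limit. Compound 4 is therefore expected at 800000 nM, with a range from 300000 nM to 3000000 nM. The expected step is a number no higher from compound 3 to compound 4 (the limit leaves the size open).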

Compound 4, half-maximal inhibitory concentration: > 800000 nM
Compound 4 ended at the assay's limit; the forecaster's own chance of this, stated with the estimate: 85%; the middle value sits exactly at the limit.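

No size can be read for any step between compound 4 and compounds 1, 2 or 3, because all four share one limit: the limit of > 800000 nM in this assay, at which 4 of the 4 values shown sit.

The compounds shown leave open whether any of these changes on the phenyl ring alters the result in this assay.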